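Removing the trifluoromethyl group from compound 1

The compounds below may be only part of what the source reports. "The series", "measured", "known", "first", "only" and "open" are said of these compounds alone.

- Compound 1 `COc1cc(-c2nn(-c3cccc(NC(=O)c4cccc(C(F)(F)F)c4)c3)cc2-c2ccncc2)ccc1Cl` gives 1240 nM
- Compound 2 `COc1cc(-c2nn(-c3cccc(NC(=O)Nc4ccc(Cl)c(Cl)c4)c3)cc2-c2ccncc2)ccc1Cl` gives 698 nM

In a functional assay on MDA-MB-231 cells (Homo sapiens) for inhibition, read by sulforhodamine B assay, with a stated time of 48 h (a lower number here means a stronger inhibitor of growth, a higher number a weaker inhibitor of growth), compound 1 at 1240 nM and compound 2 at 698 nM lie within the scatter of each other, so they cannot be ranked. Among the compounds with values here, compound 3 `COc1cc(-c2nn(-c3cccc(NC(=O)c4ccccc4)c3)cc2-c2ccncc2)ccc1Cl` keeps the rest of compound 1 and has hydrogen in place of trifluoromethyl on an aromatic carbon as its single change. Within the data shown here, only one measured step bears on this, and only loosely, since it replaces the whole group on the carbonyl carbon rather than removing one substituent. In compound 2 that larger swap gave a 1.8-fold lower number from compound 1 to compound 2 (0.25 log units; within the scatter) and so no shift beyond the scatter is expected in this assay here either, although the direction stays uncertain. The expected step is a 1.2-fold higher number from compound 1 to compound 3 (0.08 log units; within the scatter) and no more than that. Compound 3 is therefore estimated at 1500 nM with an expected range of 650 nM to 3800 nM in this measurement.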

Compound 3, concentration for 50% growth inhibition: 1170 nM
Compound 3: middle estimate off by 1.3-fold (0.11 log units), on the high side; the measured number falls inside the stated range.
By their numbers in this assay, from the lowest: compounds 2, 3 and 1 (each within the scatter of the next).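

In this assay replacing trifluoromethyl with hydrogen on the aromatic carbon turns the 3-(trifluoromethyl)phenyl group into plain phenyl, and the result (a 1.1-fold lower number from compound 1 to compound 3 (0.03 log units; within the scatter)) shows that this single substituent can go without a shift beyond the scatter. The earlier step had replaced the whole group on the carbonyl carbon, whereas this one isolates the substituent, and the swap of (3,4-dichlorophenyl)amino for phenyl (a 1.7-fold higher number from compound 2 to compound 3 (0.22 log units; within the scatter)) also stays within the scatter, so the three compounds cannot be ranked. Nothing available gives a reason for this flat result.

From the compounds shown here alone, it remains open whether an amine or a carboxylic acid on this aromatic carbon would move the number beyond the scatter. Going by these compounds, it is equally open whether a longer chain in place of the phenyl on the carbonyl carbon would do so.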